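This account rests on a few compounds, and the source may have more. Where it says the series, first, only, none or still open, it means among the compounds named here.

Measured compounds in a functional assay on HL60/MX2 cells (Homo sapiens) for antiproliferative activity, read by MTT assay, with a stated time of 48 h; a higher number here means a weaker inhibitor, a lower number a stronger inhibitor:
Compound 1 `Cn1c(N)c(-c2nc3ccccc3[nH]2)c2nc(C#N)c(C#N)nc21`: > 50000 nM, a limit.
Compound 2 `CN(C)CCCn1c(N)c(-c2nc3ccccc3[nH]2)c2nc(C#N)c(C#N)nc21`: 2390 nM.
Compound 3 `CCCCn1c(N)c(-c2nc3ccccc3[nH]2)c2nc(C#N)c(C#N)nc21`: > 50000 nM, a limit.

Compound 2 is the only one of the three with a true number. Compound 1 and compound 3 both stand at the limit of > 50000 nM in this assay, at which 2 of the 3 values shown sit. Two steps around compound 2 are large and beyond the scatter: an at least 20-fold lower number from compound 1 to compound 2 (1.32 log units; beyond the scatter) and an at least 20-fold higher number from compound 2 to compound 3 (1.32 log units; beyond the scatter). The third, a step that the two limits leave unreadable from compound 1 to compound 3, cannot be read.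

Compound 4 `CN(C)CCCn1c(N)c(-c2nc3ccccc3n2C)c2nc(C#N)c(C#N)nc21` keeps the chain of compound 2 and changes another part of the molecule: methyl in place of hydrogen on an aromatic nitrogen. This is methyl in place of hydrogen on an aromatic nitrogen, and it turns 1H-benzimidazol-2-yl into 1-methyl-1H-benzimidazol-2-yl. All three measured steps concern the chain on the other aromatic nitrogen, so none of them measures this change directly. For the measured compounds named here, they show only that one change can move this assay by a large amount, which argues for a wide range. Since compound 4 retains the chain of compound 2 (2390 nM), it is expected to give a number, probably a somewhat higher one. The expected change is a 2.5-fold higher number from compound 2 to compound 4 (0.40 log units; beyond the scatter). For compound 4 the estimated value is 6000 nM, with an expected range of 1500 nM to 30000 nM.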

Compound 4, half-maximal inhibitory concentration: 11300 nM
Estimate against measurement, compound 4: 1.9-fold (0.27 log units) below; the range from low to high includes it.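

For the compounds shown here, the earlier compounds varied only the chain on the other aromatic nitrogen, so this is the only step in this assay that reads the change from 1H-benzimidazol-2-yl to 1-methyl-1H-benzimidazol-2-yl: a 4.7-fold higher number from compound 2 to compound 4 (0.67 log units; beyond the scatter). The hydrogen on this nitrogen therefore counts for something, since replacing it with methyl moves the number beyond the scatter, yet the step is only modest, whereas the two readable steps that change the chain are large. The methyl group also leaves compound 4 with a true number, while compound 1 and compound 3 remain limits rather than numbers: the limit of > 50000 nM in this assay, at which 2 of the 4 values shown sit.

With one substituent on one chain, the compounds shown do not tell whether ethyl or benzyl on this aromatic nitrogen would move the number further than methyl does. They also leave open whether the same methyl group has a comparable effect alongside a different chain, such as a longer aminoalkyl chain or one ending in morpholine or pyrrolidine instead of dimethylamino.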